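The source may hold more compounds than are shown below. What is called first, only, known or untested is meant among the compounds shown, and "the series" means these compounds.

Working notes on the sulfonylguanidine series. Of the compounds shown here, three on the shared core have been measured: compound 1 `Cc1ccc(S(=O)(=O)NC(=N)N2CCN(c3cc4c(cc3F)c(=O)c(C(=O)O)cn4C3CC3)CC2)cc1`, compound 2 `N=C(NS(=O)(=O)c1ccc(Cl)cc1)N1CCN(c2cc3c(cc2F)c(=O)c(C(=O)O)cn3C2CC2)CC1` and compound 3 `CCn1cc(C(=O)O)c(=O)c2cc(F)c(N3CCN(C(=N)NS(=O)(=O)c4ccc(Cl)cc4)CC3)cc21`. In a functional assay on HeLa cells (Homo sapiens) for antiproliferative activity, read by MTT assay, with a stated time of 72 h (a higher number here means a weaker inhibitor, a lower number a stronger inhibitor), compound 1 gives 32 nM, compound 2 gives 32 nM and compound 3 gives 32 nM; all three stand level at the digits reported.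

Two single changes have been tested. From compound 2 to compound 1 the change is methyl in place of chloro on an aromatic carbon, and the step is no change at the digits printed from compound 2 to compound 1 (within the scatter). The cores of compound 2 and compound 3 differ by ethyl in place of cyclopropyl on an aromatic nitrogen, with the step of no change at the digits printed from compound 2 to compound 3 (within the scatter).

Compound 4 `CCn1cc(C(=O)O)c(=O)c2cc(F)c(N3CCN(C(=N)NS(=O)(=O)c4ccc(C)cc4)CC3)cc21` is not yet measured in this assay. It differs from compound 3 by methyl in place of chloro on an aromatic carbon, which is the same change already seen between compound 2 and compound 1, the surroundings of the place being described in identical words in both cases. Since the earlier step read no change at the digits printed from compound 2 to compound 1 (within the scatter), the step from compound 3 to compound 4 is expected to be no change at the digits printed from compound 3 to compound 4 (within the scatter) in this assay. Compound 4 is accordingly estimated at 32 nM, with a range from 16 nM to 64 nM.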

Compound 4, half-maximal inhibitory concentration: 32 nM
Compound 4: middle estimate and measured number agree at the digits printed; low and high end bracket the measured number.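

In this assay, methyl in place of chloro on the ethyl core reads no change at the digits printed from compound 3 to compound 4 (within the scatter), which matches the same change on the cyclopropyl core: the same change on two cores in this assay, no change at the digits printed (within the scatter) from compound 2 to compound 1 and no change at the digits printed (within the scatter) from compound 3 to compound 4, 1.0-fold (0.00 log units) apart, within the scatter of two such steps

Ethyl in place of cyclopropyl on the aromatic nitrogen, now with the 4-methylphenyl group in place, reads no change at the digits printed from compound 1 to compound 4 (within the scatter), which again matches the earlier step: the same change on two cores in this assay, no change at the digits printed (within the scatter) from compound 2 to compound 3 and no change at the digits printed (within the scatter) from compound 1 to compound 4, 1.0-fold (0.00 log units) apart, within the scatter of two such steps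

Each change therefore carries between these cores without a visible difference across these four compounds, but both changes are null on both cores, and the set says nothing about whether a step of real size would carry over in the same way.

Open, going by these compounds, is whether other groups in place of chloro and methyl on the aromatic ring, such as methoxy or a nitrile, or a longer chain on the aromatic nitrogen, would hold the same level. Also open, on these data alone, is what an amide in place of the carboxylic acid would do on either core.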